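Working notes on compound 1, compound 2 and a new analogue

A few compounds are considered here, and "the series" means these few. Any claim that something is new, unique, unknown or untested is made for them only; others in the source may bear on it.

Measured so far in an ADME assay on the whole organism with Oryza sativa as the target, tested at 1 uM; a higher number here means a weaker effect of the compound at the concentration tested, a lower number a stronger effect:
compound 1, `Cc1ccccc1NC(=O)N[C@H](C)c1ccccc1`, 100%
compound 2, `C[C@@H](NC(=O)Nc1ccccc1Cl)c1ccccc1`, 103%

Compound 1 holds the lowest of the two numbers; the nearest is compound 2, and the step of a number 3 percentage points higher from compound 1 to compound 2 (within the scatter) lies within the scatter, so the two values cannot be ordered.

The unmeasured compound 3, `Cc1cc(F)ccc1NC(=O)N[C@H](C)c1ccccc1`, differs from compound 1 by fluoro in place of hydrogen on an aromatic carbon.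

Among the measured compounds shown here, only one measured step bears on this change, and only loosely: a number 3 percentage points higher from compound 1 to compound 2 (within the scatter) also concerns a substituent on an aromatic carbon of the same ring and stayed within the scatter. Nothing measured here points to a shift beyond the scatter for a single fluoro in place of hydrogen.

Compound 3 is therefore expected at 100%, in the range 88% to 110%. The expected step of no change at the digits printed from compound 1 to compound 3 (within the scatter) stays within the scatter.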

Compound 3, a percentage reported as activity, at one concentration (the size of the read-out at that concentration, not a potency): 100%
Compound 3: middle estimate and measured number agree at the digits printed, and the stated range covers the measured number.
By their numbers in this assay, from the lowest: compounds 1, 3 and 2 (each within the scatter of the next).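

In this assay, fluoro in place of hydrogen on the aromatic carbon meta to a methyl group and para to a large group gives no change at the digits printed from compound 1 to compound 3 (within the scatter) in this series. Among the compounds shown here, the earlier step concerned a change at the carbon bearing the methyl group, whereas this one is the first reading at a ring carbon that carries hydrogen in compound 1. At this position, a single fluoro leaves the number within the scatter, so this change does not separate compound 3 from compound 1; no supporting data bear on this result.

On these data alone, whether an amine, a carboxylic acid or a longer chain in place of the fluoro would move the number beyond the scatter stays open. As far as these compounds go, the reading for fluoro on the other aromatic carbons of this ring also stays open.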